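A few compounds are considered here, and "the series" means these few. Any claim that something is new, unique, unknown or untested is made for them only; others in the source may bear on it.

In a functional assay on SGC-7901 cells (Homo sapiens) for inhibition, read by MTT assay, with a stated time of 24 h (on this read-out higher numbers stand for weaker inhibition and lower numbers for stronger inhibition), compound 1 (`CC1(C)[C@H]2CC[C@]1(C)N(Cc1cn(-c3cccc(F)c3)nn1)C(=O)C2`) gives 530 nM as its value, compound 2 (`CC1(C)[C@H]2CC[C@]1(C)N(Cc1cn(-c3ccccc3C#N)nn1)C(=O)C2`) gives 260 nM and compound 3 (`CC1(C)[C@H]2CC[C@]1(C)N(Cc1cn(-c3cccc(C#N)c3)nn1)C(=O)C2`) gives 250 nM on the same read-out. The gap (a 1.0-fold lower number from compound 2 to compound 3 (0.02 log units; within the scatter)) puts the two cyano compounds level, and together they hold the low end of the three numbers. Next comes compound 4 (`CC1(C)[C@H]2CC[C@]1(C)N(Cc1cn(-c3ccccc3F)nn1)C(=O)C2`), with 2-fluorophenyl in place of 3-cyanophenyl on an aromatic nitrogen. Two modest steps out of the fluoro compound bear on this change: cyano in place of fluoro (a 2.1-fold lower number from compound 1 to compound 3 (0.33 log units; beyond the scatter)) and 2-cyanophenyl in place of 3-fluorophenyl (a 2.0-fold lower number from compound 1 to compound 2 (0.31 log units; beyond the scatter)). Read backwards, both point to a higher number once a fluorophenyl group returns. For the measured compounds named here, no 2-fluorophenyl compound has been measured yet, so this read-across remains uncertain. The expected change (a 1.9-fold higher number from compound 3 to compound 4 (0.28 log units; within the scatter)) is a modest move to a higher number, of about the size of those two steps. For compound 4 the estimate is 480 nM within an expected range of 240 nM to 950 nM in this assay at this stage.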

Compound 4, half-maximal inhibitory concentration: 300 nM
Compound 4: the middle estimate sits 1.6-fold (0.20 log units) above what was measured, within the range that was stated.
By their numbers in this assay, from the lowest: compounds 3, 2, 4 and 1 (each within the scatter of the next, the first and the last beyond it).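

In this assay, the 2-fluorophenyl group on this aromatic nitrogen stands level with both cyanophenyl groups (a 1.2-fold higher number from compound 3 to compound 4 (0.08 log units; within the scatter) and a 1.2-fold higher number from compound 2 to compound 4 (0.06 log units; within the scatter)), so a fluorophenyl group here does not by itself separate from a cyanophenyl group. Compound 4 also stays within the scatter of its 3-fluorophenyl counterpart (a 1.8-fold lower number from compound 1 to compound 4 (0.25 log units; within the scatter)), leaving no readable difference between these two fluoro arrangements. The step from fluoro to cyano is therefore beyond the scatter only when it starts from compound 1, though the two cases cannot be told apart: the same change on two cores in this assay, a 2.1-fold lower number (0.33 log units; beyond the scatter) from compound 1 to compound 3 and a 1.2-fold lower number (0.06 log units; within the scatter) from compound 4 to compound 2, 1.8-fold (0.26 log units) apart, within the scatter of two such steps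

On these data alone, an unsubstituted phenyl group and phenyl groups bearing a methoxy group, an amine or a carboxylic acid remain open at this position. Also open, as far as these compounds go, is whether the level numbers of compounds 2, 3 and 4 would hold in other cell lines.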